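Hydroxy for amino on the amide nitrogen of compound 3

The compounds below may be only part of what the source reports. "The series", "measured", "known", "first", "only" and "open" are said of these compounds alone.

Of the compounds shown here, three have been measured in an assay on Sf9 cells for inhibition of protein deacetylase HDAC6 (Homo sapiens), read by fluorescence, with a stated time of 40 min, tested at 100 nM; a lower number here means less inhibition, a higher number more inhibition at the concentration tested (going by the name of the read-out). Compound 1 `COc1ccc(-n2nc(-c3ccccc3)nc2CNc2ccc(C(=O)NO)cc2)cc1` gives 63.4% and compound 2 `O=C(NO)c1ccc(NCc2nc(-c3ccccc3Cl)nn2-c2ccccc2)cc1` gives 75%; both carry a hydroxycarbamoyl group. Compound 3 `NNC(=O)c1ccc(NCc2nc(-c3ccccc3)nn2-c2ccccc2)cc1`, which carries an aminocarbamoyl group instead, gives 10%, the lowest of the three numbers: compound 1 lies higher by a margin beyond the scatter, and compound 2 lies higher still, also beyond the scatter. Among the compounds with values here, no pair among the measured compounds differs in a single place, so no measured step is available for the change considered next.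

Compound 4 `O=C(NO)c1ccc(NCc2nc(-c3ccccc3)nn2-c2ccccc2)cc1` differs from compound 3 by one change: hydroxy in place of amino on an amide-type nitrogen. This change, read one bond further out, takes the aminocarbamoyl end of compound 3 to the hydroxycarbamoyl end that compounds 1 and 2 share. A step upward beyond the scatter is expected, because compound 1 gives 63.4% and compound 2 gives 75% with that same group. The step expected is a number 56 percentage points higher from compound 3 to compound 4 (beyond the scatter). In this assay compound 4 is expected to give 66%, with a range from 45% to 85%.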

Compound 4, a percentage reported as inhibition, at one concentration (the size of the read-out at that concentration, not a potency): 72.6%
Beside the measured number, compound 4's estimate is 6.6 percentage points below it; the range from low to high includes it.
By their numbers in this assay, from the lowest: compound 3; then compounds 1, 4 and 2 (each within the scatter of the next, the first and the last beyond it).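

Within the data shown here, on an amide-type nitrogen, hydroxy in place of amino gives a number 62.6 percentage points higher from compound 3 to compound 4 (beyond the scatter) in this assay, a large step and the first comparison in which this change stands alone, so the low number of compound 3 goes with the amino on this nitrogen and not with the rest of the structure. Hydrogen in place of chloro on an aromatic carbon gives a number 2.4 percentage points lower from compound 2 to compound 4 (within the scatter), and hydrogen in place of methoxy on an aromatic carbon gives a number 9.2 percentage points higher from compound 1 to compound 4 (within the scatter), so with the hydroxycarbamoyl end in place neither of these two changes moves the read-out by more than the usual scatter. No measured evidence is at hand on why the change on the nitrogen has a step of this size.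

The compounds shown leave open how a methoxy or methyl group on the amide-type nitrogen, or a carboxylic acid in place of the hydroxycarbamoyl end, would read in this assay. Also open is whether chloro and methoxy would stay within the scatter with the aminocarbamoyl end, since here they appear only with the hydroxycarbamoyl end, and at one concentration the read-out gives no potency for any of these compounds.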